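Swapping one ring group at the limit of the assay

The compounds below may be only part of what the source reports. "The series", "measured", "known", "first", "only" and "open" are said of these compounds alone.

Compound 1 `COc1cccc(/C=C2\CCC/C(=C\c3ccc(Br)cc3)C2=O)c1OC`: > 20000 nM (a limit)
Compound 2 `COc1cccc(/C=C2\CCC/C(=C\c3cccc(O)c3)C2=O)c1OC`: > 20000 nM (a limit)

In a functional assay on A549 cells (Homo sapiens) for cytotoxicity, read by MTT assay, with a stated time of 72 h (on this read-out higher numbers stand for weaker inhibition and lower numbers for stronger inhibition), compound 2 gives > 20000 nM as a limit and not as a number. Both measurements so far stop at one point, namely the limit of > 20000 nM in this assay, at which 2 of the 2 values shown sit, and no number lies beyond it. Compound 3 `COc1cccc(/C=C2\CCC/C(=C\c3ccc(Cl)cc3Cl)C2=O)c1OC` changes one group (2,4-dichlorophenyl in place of 3-hydroxyphenyl on a double-bonded chain carbon bound to a double-bonded ring carbon) on the shared core. For the measured compounds named here, the only measured step that bears on this is (a step that the two limits leave unreadable from compound 1 to compound 2), so no size can be carried over from it. In this assay the expected step is (a step that the limit leaves unreadable from compound 2 to compound 3) and has no firm direction. That expectation rests on compound 2 at > 20000 nM as a limit. Compound 3 is estimated at 22000 nM (expected range 8000 nM to 50000 nM).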

Compound 3, half-maximal inhibitory concentration: > 20000 nM
Compound 3: a limit, no number; the forecaster's own chance of this, stated with the estimate: 70%; the middle value is on the limit's open side.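

For the compounds shown here, compound 3 gives > 20000 nM, a limit and not a number, so no step from compound 1 or compound 2 to it can be read. The compounds shown leave open how far apart their true values lie in this assay, since none gives a number.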